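This account rests on a few compounds, and the source may have more. Where it says the series, first, only, none or still open, it means among the compounds named here.

In a functional assay on the whole organism (strain albino) for inhibition, with Rattus norvegicus as the target, read by paw edema, with stated times of 30 min and 3 h, at a dose of 100 mg/kg by the oral route (on this read-out lower numbers stand for less inhibition and higher numbers for more inhibition at the one dose given (going by the name of the read-out)), compound 3 `COc1ccc(/C=C/C(=O)c2ccc(NC(=O)COc3ccc(C(C)=O)cc3)cc2)cc1` gives 42%. Among the three compounds measured, compound 3 sits at the low end of the numbers: compound 1 `O=C(CO[N+](=O)[O-])Nc1ccc(C(=O)/C=C/c2ccco2)cc1` gives 48%, which lies within the scatter of compound 3, while compound 2 `CC(=O)c1ccc(OCC(=O)Nc2ccc(C(=O)/C=C/c3ccc(Cl)cc3)cc2)cc1` gives 61%, beyond it. Among the compounds with values here, the only measured step, a number 19 percentage points lower from compound 2 to compound 3 (beyond the scatter), concerns the ring at the end of the chain. Compound 4 `CC(=O)c1ccc(OCC(=O)Nc2ccc(C(=O)/C=C/c3ccco3)cc2)cc1` differs from compound 3 in a different way: furan-2-yl in place of 4-methoxyphenyl on a double-bonded chain carbon bound to a double-bonded chain carbon. Within the data shown here, no measured step covers this change on its own; compound 1 carries the same furan-2-yl group but a different amide, and its number and that of compound 3 fall within the scatter of each other. The step of a number 4 percentage points higher from compound 3 to compound 4 (within the scatter) is therefore expected to be small, with no clear direction. Compound 4 is estimated at 46%, between 34% and 58%.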

Compound 4, a percentage reported as inhibition, in the whole organism at one dose (the size of the read-out at that dose, not a potency): 45%
Compound 4: the middle estimate sits 1 percentage points above what was measured; measured number inside the range.
By their numbers in this assay, from the lowest: compounds 3, 4 and 1 (each within the scatter of the next); then compound 2.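

With the rest of the molecule held constant, furan-2-yl and 4-methoxyphenyl on this double-bonded chain carbon cannot be told apart in this assay (a number 3 percentage points higher from compound 3 to compound 4 (within the scatter)). Furan-2-yl does differ from 4-chlorophenyl at the same place (a number 16 percentage points lower from compound 2 to compound 4 (beyond the scatter)), so among these three groups only 4-chlorophenyl stands apart. With furan-2-yl fixed, 4-acetylphenyl in place of nitro on the oxygen on a saturated carbon stays within the scatter (a number 3 percentage points lower from compound 1 to compound 4 (within the scatter)). Nothing at hand explains these results. On these data alone, how an amine, a carboxylic acid or a longer chain at this place would read in this assay remains open.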